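This account rests on a few compounds, and the source may have more. Where it says the series, first, only, none or still open, it means among the compounds named here.

Measured compounds in a functional assay on MDA-MB-231 cells (Homo sapiens) for cytotoxicity, read by MTT assay, with a stated time of 72 h; a higher number here means a weaker inhibitor, a lower number a stronger inhibitor:
Compound 1, `COc1ccccc1Nc1nc(SCc2ccc(C(F)(F)F)cc2)nc2ccccc12`: compound 1 reaches only the assay limit > 50000 nM.
Compound 2, `Cc1ccccc1Nc1nc(SCc2ccc(C(F)(F)F)cc2)nc2ccccc12`: compound 2 gives 27100 nM.
Compound 3, `FC(F)(F)c1ccc(CSc2nc(Nc3cccc(Br)c3)c3ccccc3n2)cc1`: compound 3 gives 22100 nM.

Compound 3 holds the lower of the two numbers, but its separation from compound 2 is within the scatter a 1.2-fold lower number from compound 2 to compound 3 (0.09 log units; within the scatter), so the two are not set apart. For compound 1 only a limit is known (the limit of > 50000 nM in this assay, at which 1 of the 3 values shown sits); the step from it to compound 3 is at least modest an at least 2.2-fold lower number from compound 1 to compound 3 (0.35 log units; beyond the scatter), and the methyl-for-methoxy exchange has a floor within the scatter an at least 1.8-fold lower number from compound 1 to compound 2 (0.26 log units; that floor lies within the scatter).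

Compound 4, `O=[N+]([O-])c1ccc(Nc2nc(SCc3ccc(C(F)(F)F)cc3)nc3ccccc23)cc1`, differs from compound 3 in one place: 4-nitrophenyl in place of 3-bromophenyl on a nitrogen on an aromatic ring. Going by the values given here, the steps that bear on this change are the two that swap the aryl group on the same nitrogen, an at least 2.2-fold lower number from compound 1 to compound 3 (0.35 log units; beyond the scatter) and a 1.2-fold lower number from compound 2 to compound 3 (0.09 log units; within the scatter); they run from at least modest to within the scatter, and neither introduces a nitrophenyl. The expected step in this assay for compound 4 is therefore small, a 1.1-fold lower number from compound 3 to compound 4 (0.04 log units; within the scatter), within the scatter. Compound 4 is estimated at 20000 nM, with a range from 8000 nM to 50000 nM.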

Compound 4, half-maximal inhibitory concentration: 8670 nM
Compound 4: the middle estimate sits 2.3-fold (0.36 log units) above what was measured; measured number inside the range.
By their numbers in this assay, from the lowest: compound 4; then compounds 3 and 2 (each within the scatter of the next). At a limit, above all of these: compound 1.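

In this assay, going by these compounds alone, the swap to 4-nitrophenyl on this nitrogen gives the first aryl steps beyond the scatter with both ends measured (a 2.5-fold lower number from compound 3 to compound 4 (0.41 log units; beyond the scatter)) and (a 3.1-fold lower number from compound 2 to compound 4 (0.49 log units; beyond the scatter)), whereas the swap between 2-methylphenyl and 3-bromophenyl stayed within it. Among the compounds shown, the aryl group on this nitrogen can therefore move the number by a modest but readable amount, and compound 4 holds the lowest number. The step from the methoxy compound (an at least 5.7-fold lower number from compound 1 to compound 4 (0.76 log units; beyond the scatter)) is only a floor, set by an assay limit: (the limit of > 50000 nM in this assay, at which 1 of the 4 values shown sits).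

As far as these compounds go, whether the step belongs to the nitro group or to its place on the ring stays open, as does how a nitrile, a carboxylic acid or an amine on that phenyl ring would read. Also open, from the compounds shown here alone, is whether the step holds when the shared core is changed elsewhere.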